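The source may report more compounds than this note shows. Statements on the series, on what has been measured and on what is new or still open speak of the compounds shown alone.

Measured so far:
- compound 1, `FC(F)(F)c1ccc(-c2ccc3c(NCCCNCc4ccco4)ccnc3c2)cc1`: 32000 nM
- compound 2, `COc1ccc(F)cc1CNCCCNc1ccnc2cc(C3CCCCC3)ccc12`: 4200 nM
- compound 3, `FC(F)(F)c1cc(-c2ccc3c(NCCCNCc4ccco4)ccnc3c2)cc(C(F)(F)F)c1`: 32000 nM

These three compounds were tested in a physicochemical assay for solubility, with a stated time of 18 h, at pH 7.4; a higher number here means a more soluble compound, a lower number a less soluble compound. Compound 1 gives 32000 nM, and compound 3 gives 32000 nM, the same number at the digits shown, so nothing separates the two within the scatter of this assay. Together they stand at the top of the three numbers. Compound 2 gives 4200 nM, a lower number, and its gap to compound 1 lies beyond the scatter.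

Compound 4 is `Fc1ccc(Cc2ccc3c(NCCCNCc4ccco4)ccnc3c2)c(Cl)c1`, not yet measured. It differs from compound 1 in one place: 2-chloro-4-fluorobenzyl in place of 4-(trifluoromethyl)phenyl on an aromatic carbon. The group leaving and the group entering are each a single six-membered aromatic ring of carbon only, carrying no hydrogen-bond donors or acceptors and no charge.

Going by the values given here, no step between measured compounds mirrors this change, so the expectation rests on compound 1 alone. The expected step is small, roughly a 1.5-fold lower number from compound 1 to compound 4 (0.16 log units; within the scatter), possibly none beyond the scatter. Compound 4 is estimated at 22000 nM, between 7000 nM and 32000 nM.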

Compound 4, solubility: 4200 nM
Compound 4: the middle estimate sits 5.2-fold (0.72 log units) above what was measured; measured number below the stated range.
By their numbers in this assay, from the lowest: compounds 2 and 4 (each within the scatter of the next); then compounds 1 and 3 (each within the scatter of the next).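

In this assay, going by these compounds alone, placing 2-chloro-4-fluorobenzyl in place of 4-(trifluoromethyl)phenyl on this aromatic carbon gives a 7.6-fold lower number from compound 1 to compound 4 (0.88 log units; beyond the scatter), the first step in the set that can be read across a single change. It shows that this position is not indifferent to what it carries, even though the leaving and entering groups each hold one six-membered aromatic ring of carbon only, with no hydrogen-bond donors or acceptors and no net charge. Nothing measured here accounts for the size of this step.

As far as these compounds go, this one step changes the ring's link to the core and the groups on that ring together, so which of these matters remains open. From the compounds shown here alone, how a plain benzyl, an amine or a carboxylic acid at this carbon would read also remains open.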